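Butoxy to 2-methoxyethoxy in a series at its limit

The source may report more compounds than this note shows. Statements on the series, on what has been measured and on what is new or still open speak of the compounds shown alone.

In an ADME assay on RAW264.7 cells (Mus musculus) for cytotoxicity, read by MTT assay, with a stated time of 24 h, in the absence of a further agent (a lower number here means a stronger inhibitor, a higher number a weaker inhibitor), compound 1 (`O=C1OC(Cc2nc(-c3ccc(Oc4ccccc4)cc3)no2)c2ccccc21`) gives > 40000 nM as a limit and not a number. Compound 2 (`COc1ccc(C(O)C2OC(=O)c3c(OC)cc(OC)cc32)cc1`) gives > 40000 nM as a limit too. Compound 3 (`CCCCOc1ccc(C(O)C2OC(=O)c3c(OC)cc(OC)cc32)cc1`) gives > 40000 nM as a limit as well, so it has no readable number. Among the compounds with values here, the series so far rests on the limit of > 40000 nM in this assay, at which 3 of the 3 values shown sit, and offers no measured value to work from.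

Compound 4 (`COCCOc1ccc(C(O)C2OC(=O)c3c(OC)cc(OC)cc32)cc1`) differs from compound 3 by butoxy to 2-methoxyethoxy (methoxy in place of ethyl on a saturated chain carbon, two bonds along the chain from an oxygen on an aromatic ring) on the shared core. Within the data shown here, the one measured step that bears on this change is a step that the two limits leave unreadable from compound 2 to compound 3 and it gives no size to carry over. No step beyond the usual scatter is expected in this assay and no direction can be named. The expected change is a step that the limit leaves unreadable from compound 3 to compound 4 in this estimate. Compound 4 is estimated at 50000 nM with an expected range from 30000 nM to 100000 nM and will most likely be reported only as a limit.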

Compound 4, half-maximal inhibitory concentration: > 40000 nM
Compound 4: only a limit was reported; the forecaster's own chance of this, stated with the estimate: 90%; the middle value is on the limit's open side.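

No new step can be read: compound 4 set against compound 3 or compound 2 compares only limits. The series stays where it was: the limit of > 40000 nM in this assay, at which 4 of the 4 values shown sit. The compounds shown leave open whether butoxy and 2-methoxyethoxy differ at all, and at what concentration any of these compounds becomes cytotoxic.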